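This account rests on a few compounds, and the source may have more. Where it says the series, first, only, none or still open, it means among the compounds named here.

For the measured compounds named here, compound 2 `Cc1cc(C)c(S(=O)(=O)N2CCC(N3CCC(CCO)CC3)CC2)c(C)c1` holds the lowest number so far: in a functional assay on DLD-1 cells (Homo sapiens) for antiproliferative activity, read by CellTiter-Glo, with a stated time of 72 h (on this read-out lower numbers stand for stronger inhibition and higher numbers for weaker inhibition), compound 2 gives 19 nM. Compound 1 `Cc1cc(C)c(S(=O)(=O)N2CCC(N3CCC(c4ccccc4)CC3)CC2)c(C)c1`, phenyl in place of 2-hydroxyethyl, gives 865 nM in this assay, the step being a 46-fold lower number from compound 1 to compound 2 (1.66 log units; beyond the scatter). Compound 3 `Cc1cc(C)c(S(=O)(=O)N2CCC(c3ccccc3)CC2)c(C)c1` reaches only a limit in this assay, > 5000 nM. That step, an at least 260-fold higher number from compound 2 to compound 3 (2.42 log units; beyond the scatter), removes the whole piperidinyl piece and is less informative here. Compound 4 `Cc1cc(C)c(S(=O)(=O)N2CCC(N3CCC(Cc4ccc(F)cc4)CC3)CC2)c(C)c1` differs from compound 2 by 4-fluorophenyl in place of hydroxymethyl on a saturated chain carbon bound to a saturated ring carbon; cut one bond further out, the change reads 2-hydroxyethyl to 4-fluorobenzyl. Going by the values given here, only the step of a 46-fold lower number from compound 1 to compound 2 (1.66 log units; beyond the scatter) bears on this, run in reverse, so a higher number is expected for compound 4, estimated as a 16-fold higher number from compound 2 to compound 4 (1.20 log units; beyond the scatter). For compound 4 the value in this assay is expected at 300 nM, between 60 nM and 2000 nM.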

Compound 4, half-maximal inhibitory concentration: 18 nM
Estimate against measurement, compound 4: 17-fold (1.22 log units) above, outside the stated range (below it).
By their numbers in this assay, from the lowest: compounds 4 and 2 (each within the scatter of the next); then compound 1. At a limit, above all of these: compound 3.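

In this assay the change from 2-hydroxyethyl to 4-fluorobenzyl gives a 1.1-fold lower number from compound 2 to compound 4 (0.02 log units; within the scatter) and shows that two very different groups can read alike at this place, one without a hydrogen-bond donor or acceptor. An aromatic ring in this side chain does not by itself give the weak reading of compound 1: 4-fluorobenzyl in place of phenyl on a saturated ring carbon gives a 48-fold lower number from compound 1 to compound 4 (1.68 log units; beyond the scatter) in the same assay. No measurement shown accounts for this.

Still open, from the compounds shown here alone, is how wide the tolerance at this place runs. A plain benzyl, an amine, a carboxylic acid or a longer chain would test it.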